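A few compounds are considered here, and "the series" means these few. Any claim that something is new, unique, unknown or untested is made for them only; others in the source may bear on it.

Compound 1 `CCCC1CCN(CCCCC(=O)c2cc(Cl)c(N)cc2OCc2cc(OC)cc(OC)c2)CC1`: 7.7
Compound 2 `COc1cc(COc2cc(N)c(Cl)cc2C(=O)CCCCN2CCC(c3ccccc3)CC2)cc(OC)c1`: 7.7
Compound 3 `COc1cc(COc2cc(N)c(Cl)cc2C(=O)CCCCN2CCC(C(N)=O)CC2)cc(OC)c1`: 8.4

In a functional assay for antagonist activity at 5-hydroxytryptamine receptor 4 (Rattus norvegicus) (a lower number here means a less potent compound, a higher number a more potent compound, by a factor of ten per unit of this negative logarithm), compound 3 gives the highest number of the three, standing a number 0.70 log units higher from compound 1 to compound 3 (beyond the scatter) and a number 0.70 log units higher from compound 2 to compound 3 (beyond the scatter). Compound 4 `COc1cc(COc2cc(N)c(Cl)cc2C(=O)CCCCN2CCC(NS(C)(=O)=O)CC2)cc(OC)c1` differs from compound 3 in one place: methanesulfonamido in place of carbamoyl on a saturated ring carbon. Going by the values given here, two measured steps bear on this change, the two that reach compound 3, in each of which a group without hydrogen-bond donors or acceptors on that saturated ring carbon was replaced by carbamoyl, and the number rose by the same modest amount; by contrast no change at the digits printed from compound 1 to compound 2 (within the scatter) shows that exchanging one such group for another left the number unchanged. Resting on a number 0.70 log units higher from compound 1 to compound 3 (beyond the scatter) and a number 0.70 log units higher from compound 2 to compound 3 (beyond the scatter), and noting that methanesulfonamido also carries one hydrogen-bond donor, the number for compound 4 is expected to stay close to that of compound 3, a step of a number 0.20 log units lower from compound 3 to compound 4 (within the scatter). Compound 4 is estimated at 8.2, between 7.5 and 8.9.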

Compound 4, negative logarithm of the antagonist equilibrium constant: 8.4
Compound 4: middle estimate off by 0.20 log units, on the low side; measured number inside the range.
By their numbers in this assay, from the lowest: compounds 1 and 2 (each within the scatter of the next); then compounds 3 and 4 (each within the scatter of the next).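

In this assay the carbamoyl on this saturated ring carbon can give way to the larger methanesulfonamido, with no change at the digits printed from compound 3 to compound 4 (within the scatter). The rise over the groups without a hydrogen-bond donor also returns with this second group, with a number 0.70 log units higher from compound 2 to compound 4 (beyond the scatter) and a number 0.70 log units higher from compound 1 to compound 4 (beyond the scatter), so it is not particular to carbamoyl. No supporting measurement is available to explain this shared rise. Still open, going by these compounds, is how a plain amine or a carboxylic acid would fare on this carbon. Dimethylcarbamoyl, which lacks the amide hydrogen, would test whether that hydrogen matters.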